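The compounds below may be only part of what the source reports. "The series", "measured", "known", "first", "only" and "open" are said of these compounds alone.

Compound 2 `CC(C)c1n[nH]c2c(NCc3ccc(-c4ccccn4)cc3)nc(SCC(O)CN)nc12` gives 55 nM in a functional assay on HT cells (Homo sapiens) for antiproliferative activity, read by fluorescence, with a stated time of 72 h; on this read-out higher numbers stand for weaker inhibition of growth and lower numbers for stronger inhibition of growth. Among the three measured compounds it holds the second highest number: compound 1 `CC(C)c1n[nH]c2c(NCc3ccc(-c4ccccn4)cc3)nc(SCCO)nc12`, with 48 nM, sits within the scatter of it, while compound 3 `CC(C)c1n[nH]c2c(NCc3ccc(-c4ccccn4)cc3)nc(SC(CO)C(C)C)nc12`, with 980 nM, lies far beyond. Compound 4 `CC(C)c1n[nH]c2c(NCc3ccc(-c4ccccn4)cc3)nc(SC3CCCC3O)nc12` has not yet been measured. It differs from compound 2 in one place: 2-hydroxycyclopentyl in place of 3-amino-2-hydroxypropyl on a sulfur. Going by the values given here, two measured steps bear on this change. a 20-fold higher number from compound 1 to compound 3 (1.31 log units; beyond the scatter), and an 18-fold higher number from compound 2 to compound 3 (1.25 log units; beyond the scatter); in both, the group on the sulfur is replaced by one with more carbon branching, and growth inhibition weakens sharply. By contrast, a 1.1-fold higher number from compound 1 to compound 2 (0.06 log units; within the scatter), so extra polar atoms on the chain changed little. Compound 4 places a 2-hydroxycyclopentyl on the sulfur, a ring with more heavy atoms than the open chain it replaces, so a loss resembling that seen with compound 3 is expected, though perhaps somewhat smaller. For compound 4 a step of a 7.3-fold higher number from compound 2 to compound 4 (0.86 log units; beyond the scatter) is expected. Compound 4 is therefore estimated at 400 nM, within 120 nM to 1500 nM.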

Compound 4, concentration for 50% growth inhibition: 567 nM
Compound 4: the middle estimate sits 1.4-fold (0.15 log units) below what was measured, within the range that was stated.
By their numbers in this assay, from the lowest: compounds 1 and 2 (each within the scatter of the next); then compounds 4 and 3 (each within the scatter of the next).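

In this assay, a 2-hydroxycyclopentyl on the sulfur gives a 10-fold higher number from compound 2 to compound 4 (1.01 log units; beyond the scatter) and a 12-fold higher number from compound 1 to compound 4 (1.07 log units; beyond the scatter), while a 1.7-fold lower number from compound 3 to compound 4 (0.24 log units; within the scatter), so this ring joins the branched chain of compound 3 in the higher range of numbers. The second of those steps starts from 2-hydroxyethyl, which carries no amine either, so losing the amine of 3-amino-2-hydroxypropyl cannot by itself explain the rise, and a hydroxyl on the group does not by itself keep the number low. Nothing available here explains why these two groups give higher numbers.

The compounds shown leave open whether the ring itself or the way the hydroxyl is held on it matters. A plain cyclopentyl, a 2-hydroxycyclohexyl or an open 3-hydroxypropyl chain on the same sulfur would help to separate these possibilities.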